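Cytotoxicity in HepG2 cells across three quinoline ethers and one biaryl

The source may report more compounds than this note shows. Statements on the series, on what has been measured and on what is new or still open speak of the compounds shown alone.

Of the compounds shown here, three have been measured in an ADME assay on HepG2 cells (Homo sapiens) for cytotoxicity, read by luminescence, CellTiter-Glo and ATP content, with a stated time of 72 h; a lower number here means that less compound is needed, a higher number that more compound is needed for the effect. Compound 1 `COc1ccccc1Oc1ccc2c(NCCCNCc3ccco3)ccnc2c1` gives 6500 nM. Compound 2 `COc1cccc(CNCCCNc2ccnc3cc(Cc4ccc(F)cc4)ccc23)c1O` gives 4780 nM. Compound 3 `COc1cccc(CNCCCNc2ccnc3cc(Oc4cccc(N(C)C)c4)ccc23)c1O` gives 7300 nM. Compound 3 shows the highest of the three numbers, but its nearest neighbour is compound 1 and its furthest is compound 2, and both gaps lie within the usual scatter, so the three compounds cannot be told apart on these figures.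

Among the compounds with values here, the only step between two measured compounds that differ in one place is a 1.5-fold higher number from compound 2 to compound 3 (0.18 log units; within the scatter), a change at the same place on the shared core that compound 4 now alters again.

Compound 4 `COc1cccc(CNCCCNc2ccnc3cc(-c4ccc(C(C)(C)C)cc4)ccc23)c1O` differs from compound 3 as follows: 4-(tert-butyl)phenyl in place of 3-(dimethylamino)phenoxy on an aromatic carbon. Within the data shown here, no measured step covers this particular exchange. Among the measured compounds shown here, the one step that touches the same position, a 1.5-fold higher number from compound 2 to compound 3 (0.18 log units; within the scatter), stayed inside the scatter, and the three measured values all sit close together. The step from compound 3 to compound 4 in this assay is therefore expected to be a 1.2-fold lower number from compound 3 to compound 4 (0.09 log units; within the scatter), with no direction beyond the scatter foreseen. Compound 4 is thus estimated at 6000 nM, with a range from 2500 nM to 15000 nM.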

Compound 4, half-maximal effective concentration: 690 nM
Beside the measured number, compound 4's estimate is 8.7-fold (0.94 log units) above it; the measured number lies below the stated range.
By their numbers in this assay, from the lowest: compound 4; then compounds 2, 1 and 3 (each within the scatter of the next).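

At this aromatic carbon of the shared core, the earlier exchange had stayed within the scatter in this assay, with a 1.5-fold higher number from compound 2 to compound 3 (0.18 log units; within the scatter), so the position had not yet shown any clear effect on the number. The new result shows that it can, with an 11-fold lower number from compound 3 to compound 4 (1.02 log units; beyond the scatter), and the change is beyond the scatter. The shift also holds against the other group measured here, with a 6.9-fold lower number from compound 2 to compound 4 (0.84 log units; beyond the scatter), so 4-(tert-butyl)phenyl stands apart from both 3-(dimethylamino)phenoxy and 4-fluorobenzyl, even though 3-(dimethylamino)phenoxy and 4-(tert-butyl)phenyl have the same count of heavy atoms and the same kind of ring.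

Nothing available explains why the number falls with this exchange. The compounds shown also leave open whether the shift belongs to the tert-butyl group or to the aromatic ring being joined directly to the core, a question that an unsubstituted phenyl or a 4-(tert-butyl)phenoxy group at the same carbon would address.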